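Dropping a Fluoro Group: Expected Effect on Writhing Inhibition

The source may hold more compounds than are shown below. What is called first, only, known or untested is meant among the compounds shown, and "the series" means these compounds.

Measured so far:
compound 1, `c1ccc(COc2nc3ccccc3s2)cc1`: 51.9%
compound 2, `Fc1ccccc1COc1nc2ccccc2s1`: 51.9%
compound 3, `Fc1ccc(OCCOc2nc3ccccc3s2)cc1`: 99.9%

All three were tested in a functional assay on the whole organism with Mus musculus as the target, in the writhing test, at a dose of 100 mg/kg by the intraperitoneal route; a lower number here means less inhibition, a higher number more inhibition at the dose given (going by the name of the read-out). Compound 1 gives 51.9% and compound 2 gives 51.9%; they differ in one place, (hydrogen in place of fluoro on an aromatic carbon), and the step of no change at the digits printed from compound 2 to compound 1 (within the scatter). Compound 3 gives 99.9%, the highest of the three, and its gap to each of the other two lies beyond the scatter. How the core of compound 3 differs from that of compound 2 is not broken down here.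

Compound 4 `c1ccc(OCCOc2nc3ccccc3s2)cc1` has not been measured yet. It differs from compound 3 by hydrogen in place of fluoro on an aromatic carbon. This is the same kind of change as from compound 2 to compound 1, but not the same change: there the fluoro sat ortho to a large group, here it sits para to a large group. A small step is expected because the matching step no change at the digits printed from compound 2 to compound 1 (within the scatter) stayed within the scatter. The expected step of a number 7.9 percentage points lower from compound 3 to compound 4 (within the scatter) rests on that single earlier step. Compound 4 is therefore expected to give 92%, between 70% and 100%.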

Compound 4, a percentage reported as inhibition, in the whole organism at one dose (the size of the read-out at that dose, not a potency): "not active" (no number reported)
For compound 4 the study gives words and no number, so the estimate cannot be set against anything.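

For the compounds shown here, the study reports compound 4 only in words, as not active, so no numerical step from compound 3 to compound 4 can be read. No data shown here explain this result. The compounds shown leave open how large the gap between compound 3 and compound 4 is in numbers.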